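The compounds below may be only part of what the source reports. "The series", "measured", "known", "first", "only" and "open" are said of these compounds alone.

Working notes on the series.

Compound 1 `C#CCNC1CCc2c(SCCc3cccc(C)c3)cccc21` is the reference point. For the measured compounds named here, in an ADME assay on isolated protein for inhibition of Amine oxidase [flavin-containing] B (Homo sapiens) (a lower number here means a stronger inhibitor, a higher number a weaker inhibitor), compound 1 gives 4960 nM, which stands as the highest of the two numbers measured so far; its nearest neighbour is compound 2 `C#CCNC1CCc2c(SCCc3cccc(C(F)(F)F)c3)cccc21`, which in this assay gives 280 nM. Going by the values given here, the one measured step within the pair is an 18-fold lower number from compound 1 to compound 2 (1.25 log units; beyond the scatter).

Compound 3 `C#CCNC1CCc2c(SCCc3ccc(OC)cc3)cccc21` has not yet been measured. Relative to compound 1 the change is 4-methoxyphenyl in place of 3-methylphenyl on a saturated chain carbon, two bonds along the chain from a sulfur. Among the compounds with values here, no measured step covers this exchange directly; the step from compound 1 to compound 2 concerns a different group on the same aromatic ring and shows only that a change on that ring can move this assay by a large amount. That step therefore gives no direction for compound 3, and the expectation for compound 3 rests on a wide range.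

For compound 3 the estimate in this assay is 3000 nM, expected to lie between 500 nM and 15000 nM. This estimate means an expected step of a 1.7-fold lower number from compound 1 to compound 3 (0.22 log units; within the scatter), small against the size seen from compound 1 to compound 2.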

Compound 3, half-maximal inhibitory concentration: 4590 nM
Estimate against measurement, compound 3: 1.5-fold (0.18 log units) below; the range from low to high includes it.
By their numbers in this assay, from the lowest: compound 2; then compounds 3 and 1 (each within the scatter of the next).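

In this assay, 4-methoxyphenyl in place of 3-methylphenyl gives a 1.1-fold lower number from compound 1 to compound 3 (0.03 log units; within the scatter) and so leaves the two compounds indistinguishable, even though the ring substituent differs in both identity and location and an oxygen enters. Set against an 18-fold lower number from compound 1 to compound 2 (1.25 log units; beyond the scatter) on the same ring, this shows that a change on this aromatic ring need not move the number by a large amount: among the compounds shown, only trifluoromethyl in place of methyl does so. No measurement at hand bears on why the two steps differ so much in size.

Compound 3 alters the substituent and its location at once, so the pair cannot show whether either change alone would leave the number as it stands, or whether two separate effects happen to cancel. A 3-methoxyphenyl or a 4-methylphenyl group would separate these two changes, while a 4-(trifluoromethyl)phenyl group would show whether the low number of compound 2 at 280 nM holds when the trifluoromethyl group sits elsewhere on the ring.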